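This account rests on a few compounds, and the source may have more. Where it says the series, first, only, none or still open, it means among the compounds named here.

Measured compounds:
- compound 1, `CCC(C)(C)Cc1c[nH]c(CCc2ccc(-c3ccccc3OCc3nc(N)n[nH]3)cc2)n1`, in a functional assay for agonist activity at Bombesin receptor subtype-3 (Homo sapiens) (a higher number here means that more compound is needed for the effect, a lower number that less compound is needed), compound 1 gives 78 nM
- compound 2, `CCC(C)(C)Cc1c[nH]c(CCc2ccc(N3CCCC[C@@H]3C(=O)O)cc2)n1`, in this assay compound 2 gives 24 nM

Compound 2 holds the lower of the two numbers; the gap to compound 1 lies beyond the usual scatter, so compound 2 stands ahead of compound 1 on what has been measured.

Compound 3, `CCC(C)(C)Cc1c[nH]c(CCc2ccc(N3CCCC[C@@H]3c3ncn[nH]3)cc2)n1`, has not yet been measured. It differs from compound 2 in one place: 1H-1,2,4-triazol-5-yl in place of carboxy on a saturated ring carbon. Among the compounds with values here, no comparable step between two measured compounds exists, so the size of the effect is open. The change swaps one hydrogen-bond donor group for another; compound 1 carries a related five-membered aromatic ring elsewhere and gives a higher number than compound 2, which is the only hint available. Compound 3 is therefore expected to sit somewhat above compound 2 in this assay, by a step of a 2.5-fold higher number from compound 2 to compound 3 (0.40 log units; beyond the scatter) that could fall within the scatter or slightly beyond it. The estimate for compound 3 is 60 nM, with a range from 15 nM to 250 nM.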

Compound 3, half-maximal effective concentration: 42 nM
For compound 3 the middle estimate is 1.4-fold (0.15 log units) above the measured one; the range from low to high includes it.
By their numbers in this assay, from the lowest: compounds 2, 3 and 1 (each within the scatter of the next, the first and the last beyond it).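

On the saturated ring carbon next to the ring nitrogen, 1H-1,2,4-triazol-5-yl can stand in place of carboxy in this assay with only a 1.8-fold higher number from compound 2 to compound 3 (0.24 log units; within the scatter) as the result, so compound 2 and compound 3 cannot be separated here. Within the data shown here, a carboxy group is thus not needed at this place for a number of this size, which the earlier compounds could not show. The place also accepts a group with more heavy atoms and a five-membered aromatic ring, and neither group carries a net charge.

In this assay, from the compounds shown here alone, it remains open how a methyl ester, a primary amine or a longer chain ending in a carboxylic acid would read on this ring carbon. Nothing at hand explains why the two groups give numbers this close.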